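Removing a Methyl from the Phenol Ether

The compounds below may be only part of what the source reports. "The series", "measured", "known", "first", "only" and "open" are said of these compounds alone.

The measured compounds and their values:
compound 1, `Cc1cccc(/C=N/c2ccc(OCc3ccccc3)cc2)c1O`, 15500 nM;
compound 2, `COc1cccc(/C=N/c2ccc(OCc3ccccc3)cc2)c1O`, 6500 nM;
compound 3, `Oc1ccc(O)c(/C=N/c2ccc(OCc3ccccc3)cc2)c1`, 1230 nM.

These values come from an assay on isolated protein for inhibition of Amine oxidase [flavin-containing] B (Homo sapiens), read by fluorescence and Amplex Red, with stated times of 15 min and 20 min; a lower number here means a stronger inhibitor, a higher number a weaker inhibitor. Compound 2 sits second highest of the three numbers: compound 1 lies a 2.4-fold lower number from compound 1 to compound 2 (0.38 log units; beyond the scatter) away, and compound 3 stands well below it. The change of methyl to methoxy on the aromatic ring gave a 2.4-fold lower number from compound 1 to compound 2 (0.38 log units; beyond the scatter), while swapping in the 2,5-dihydroxyphenyl for the 2-hydroxy-3-methylphenyl gave a 13-fold lower number from compound 1 to compound 3 (1.10 log units; beyond the scatter).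

Compound 4, `Oc1cccc(/C=N/c2ccc(OCc3ccccc3)cc2)c1O`, is not yet measured. It differs from compound 2 by hydrogen in place of methyl on an oxygen on an aromatic ring. Among the measured compounds shown here, no measured pair shows exactly this change; the methoxy-to-hydroxy reading is only loosely echoed by compound 3, whose two hydroxyls go with the lowest number. On that basis compound 4 is expected to give a modest improvement in this assay, estimated as a 1.9-fold lower number from compound 2 to compound 4 (0.27 log units; within the scatter). The estimated value for compound 4 is 3500 nM, within a range of 1200 nM to 9000 nM.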

Compound 4, half-maximal inhibitory concentration: 6870 nM
Compound 4: the middle estimate sits 2.0-fold (0.29 log units) below what was measured; low and high end bracket the measured number.
By their numbers in this assay, from the lowest: compound 3; then compounds 2 and 4 (each within the scatter of the next); then compound 1.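

In this assay, replacing methoxy with hydroxy at this position makes no change that can be told apart, since a 1.1-fold higher number from compound 2 to compound 4 (0.02 log units; within the scatter) stays within the scatter; the methyl on this oxygen can be removed without a visible gain or loss. The hydroxy also matches the methoxy in its advantage over a methyl on the aromatic carbon, with a 2.3-fold lower number from compound 1 to compound 4 (0.35 log units; beyond the scatter) alongside a 2.4-fold lower number from compound 1 to compound 2 (0.38 log units; beyond the scatter). The placement of the second hydroxy counts for more than the methyl on this oxygen, as the 2,3-dihydroxyphenyl compound gives a 5.6-fold higher number from compound 3 to compound 4 (0.75 log units; beyond the scatter).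

Nothing here explains why the hydroxy and methoxy compounds read alike. As far as these compounds go, it also remains open whether an ethyl or benzyl on this oxygen, or an amine in place of the hydroxy, would move the number beyond the scatter.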